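This account rests on a few compounds, and the source may have more. Where it says the series, first, only, none or still open, it means among the compounds named here.

Compound 3 `C=CCOC(=O)C1=C(C)NC(C)=C(C(=O)OC)C1c1cccc([N+](=O)[O-])c1` is the starting point. In a functional assay on HEK293 cells for antagonist activity at Voltage-dependent L-type calcium channel subunit alpha-1D (Rattus norvegicus), read by FLIPR (a lower number here means a stronger inhibitor, a higher number a weaker inhibitor), compound 3 gives 15 nM, the second highest of the three numbers. Compound 2 `C=CCOC(=O)C1=C(C)NC(C)=C(C(=O)OC)C1c1ccccc1[N+](=O)[O-]` gives 10 nM, and the step of a 1.5-fold higher number from compound 2 to compound 3 (0.18 log units; within the scatter) lies within the scatter. Compound 1 `CCOC(=O)C1=C(C)NC(CO)=C(C(=O)OCC)C1c1cccc([N+](=O)[O-])c1` gives 45 nM; it differs from compound 3 in more than one place, so its higher number cannot be tied to any single change. Compound 4 `COC(=O)C1=C(C)NC(C)=C(C(=O)OCc2ccc(OC)cc2)C1c1cccc([N+](=O)[O-])c1` differs from compound 3 as follows: 4-methoxyphenyl in place of vinyl on a saturated chain carbon bound to an oxygen next to a carbonyl group. For the measured compounds named here, no measured step touches the ester chain, and the only measured step, from compound 2 to compound 3, stayed small. Without a guide, the step of no change at the digits printed from compound 3 to compound 4 (within the scatter) is expected to stay within the scatter. Compound 4 is expected to give about 15 nM, between 5 nM and 50 nM.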

Compound 4, half-maximal inhibitory concentration: 79 nM
Beside the measured number, compound 4's estimate is 5.3-fold (0.72 log units) below it; measured number above the stated range.
By their numbers in this assay, from the lowest: compounds 2 and 3 (each within the scatter of the next); then compounds 1 and 4 (each within the scatter of the next).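

Swapping allyl for 4-methoxybenzyl on the ester chain gives, in this assay, a 5.3-fold higher number from compound 3 to compound 4 (0.72 log units; beyond the scatter) as the first measured step at this position. For the compounds shown here, it shows that the number responds to what this ester carries, whereas the only earlier step, a 1.5-fold higher number from compound 2 to compound 3 (0.18 log units; within the scatter), concerned the nitrophenyl group. No measurement available here explains the weaker inhibition. Whether the aromatic ring or its methoxy group accounts for the step stays open. So does how an unsubstituted benzyl, a longer chain or an amine-bearing chain would compare at this position.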